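The source may report more compounds than this note shows. Statements on the series, on what has been measured and on what is new or still open speak of the compounds shown alone.

Measured compounds:
compound 1 `CCOC(=O)[C@@H]1CCCN(S(=N)(=O)c2ccc(S(=O)(=O)N(CC)CC)cc2)C1` gives 4700 nM
compound 2 `CCN(CC)S(=O)(=O)c1ccc(S(=O)(=O)N2CCC[C@@H](C(=O)NC3CN(C(=O)C4CC4)C3)C2)cc1` gives 3100 nM

Both numbers come from a functional assay on MIA PaCa-2 cells (Homo sapiens) for inhibition, read by MTT assay, with a stated time of 3 days; on this read-out higher numbers stand for weaker inhibition and lower numbers for stronger inhibition. Compound 2 has the lower of the two numbers, with compound 1 close by at a gap that stays within the usual scatter, so the two cannot be ranked against each other.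

The step to be considered leads from compound 2 to compound 3 `CCN(CC)S(=O)(=O)c1ccc(S(=O)(=O)N2CCC[C@@H](C(=O)NC3COC3)C2)cc1`. The difference between them is a single exchange, oxetan-3-yl in place of 1-(cyclopropylcarbonyl)azetidin-3-yl on an amide-type nitrogen. Among the compounds with values here, no measured pair shows this exchange, so there is nothing to calibrate the step against, and the two measured values alone give no direction for it.

On this basis the expected step from compound 2 to compound 3 in this assay is a 1.3-fold higher number from compound 2 to compound 3 (0.11 log units; within the scatter), a shift that is not expected to clear the scatter. The estimate for compound 3 in this assay is therefore 4000 nM, with a likely range from 1500 nM to 11000 nM.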

Compound 3, half-maximal inhibitory concentration: 900 nM
Compound 3: middle estimate off by 4.4-fold (0.65 log units), on the high side, and the stated range ends above it.
By their numbers in this assay, from the lowest: compound 3; then compounds 2 and 1 (each within the scatter of the next).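

In this assay, the group on the amide-type nitrogen now shows a readable effect, which the close values of compound 1 and compound 2 could not: oxetan-3-yl in place of 1-(cyclopropylcarbonyl)azetidin-3-yl gives a 3.4-fold lower number from compound 2 to compound 3 (0.54 log units; beyond the scatter) and this step lies beyond the usual scatter. The entering group has 4 heavy atoms against 9 in the group that leaves, so in this one pair the cyclopropylcarbonyl part and the larger group as a whole are not needed for the stronger inhibition seen with compound 3. No measurement shown here accounts for the drop in the number.

On these data alone, this single step changes two things together, removing the cyclopropylcarbonyl part and exchanging the ring nitrogen for an oxygen, so it remains open which of them goes with the stronger inhibition. A plain azetidin-3-yl with its ring amine free would help to separate the two, while a cyclobutyl ring of carbon only would test whether any ring hetero atom is needed at this position.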